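This account rests on a few compounds, and the source may have more. Where it says the series, first, only, none or still open, it means among the compounds named here.

For the measured compounds named here, in a functional assay on HeLa cells (Homo sapiens) for inhibition (a lower number here means a stronger inhibitor, a higher number a weaker inhibitor), compound 1 `O=C(O)CSC(CC(=O)c1ccccc1)C(=O)O` gives 15000 nM, the higher of the two numbers so far, and compound 2 `Cc1ccc(C(=O)CC(SCC(=O)O)C(=O)O)cc1C` gives 3810 nM, a gap beyond the scatter. Compound 3 `CCCCc1ccc(C(=O)CC(SCC(=O)O)C(=O)O)cc1` has not yet been measured. It carries butyl in place of hydrogen on an aromatic carbon, para to a large group (butyl in place of hydrogen on an aromatic carbon). Going by the values given here, no measured step covers this change, so the only guide is compound 2 at 3810 nM, which also has a substituted version of that ring. A clear move toward stronger inhibition is expected, with an estimated 6.0-fold lower number from compound 1 to compound 3 (0.78 log units; beyond the scatter). Compound 3 is estimated at 2500 nM, with an expected range of 600 nM to 9000 nM.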

Compound 3, half-maximal inhibitory concentration: 1920 nM
Beside the measured number, compound 3's estimate is 1.3-fold (0.11 log units) above it; low and high end bracket the measured number.
By their numbers in this assay, from the lowest: compounds 3 and 2 (each within the scatter of the next); then compound 1.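

In this assay, for the compounds shown here, butyl in place of hydrogen on an aromatic carbon, para to a large group, gives a 7.8-fold lower number from compound 1 to compound 3 (0.89 log units; beyond the scatter), the only step here that changes a single place. This shows that the position accepts butyl with a gain in inhibition rather than a loss. No measurement here gives a reason for that gain. On these data alone, whether a shorter chain such as ethyl, a longer chain such as hexyl, or a methoxy group would do as well at this position stays open. So does whether both carboxylic acids of the shared core are needed.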